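The source may report more compounds than this note shows. Statements on the series, on what has been measured and on what is new or still open speak of the compounds shown alone.

Three compounds share one core and differ only in what sits on the six-membered aromatic ring of carbon only. In an assay on isolated protein for inhibition of Dopamine beta-hydroxylase (Rattus norvegicus) (a higher number here means a weaker inhibitor, a lower number a stronger inhibitor), compound 1 `COc1ccccc1Cn1cc[nH]c1=S` gives 74100 nM, compound 2 `S=c1[nH]ccn1Cc1cccc(Cl)c1Cl` gives 52500 nM, and compound 3 `S=c1[nH]ccn1Cc1ccccc1Cl` gives 355000 nM. Compound 3 thus carries the highest number of the three and is the weakest inhibitor among them, since both the step of a 4.8-fold higher number from compound 1 to compound 3 (0.68 log units; beyond the scatter) and the step of a 6.8-fold higher number from compound 2 to compound 3 (0.83 log units; beyond the scatter) lie beyond the scatter.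

Compound 4 `S=c1[nH]ccn1Cc1cc(Cl)ccc1Cl` has not yet been measured. It differs from compound 3 by chloro in place of hydrogen on an aromatic carbon. The measured step that bears most directly on this change is a 6.8-fold higher number from compound 2 to compound 3 (0.83 log units; beyond the scatter), in which taking a chloro off the ring raised the number; compound 4 puts a chloro back, though meta to a group of 7 heavy atoms and para to a chloro group rather than where compound 2 has it. The step of a 4.8-fold higher number from compound 1 to compound 3 (0.68 log units; beyond the scatter) also shows that a single change on this ring moves the number by a modest amount. Among the measured compounds shown here, a modest downward step is therefore expected, a 4.4-fold lower number from compound 3 to compound 4 (0.65 log units; beyond the scatter), with some caution since no measured pair tests this exact placement. For compound 4 in this assay the estimate is 80000 nM, with a likely range from 30000 nM to 250000 nM.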

Compound 4, half-maximal inhibitory concentration: 97700 nM
The estimate for compound 4 lay 1.2-fold (0.09 log units) below the measured number; the measured number falls inside the stated range.
By their numbers in this assay, from the lowest: compounds 2, 1 and 4 (each within the scatter of the next); then compound 3.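

In this assay, adding a chloro meta to a group of 7 heavy atoms and para to a chloro group gives a 3.6-fold lower number from compound 3 to compound 4 (0.56 log units; beyond the scatter), the first measured case of a chloro being added at this place on the ring. Among the compounds shown here, until now, the only evidence for a second chloro came from a 6.8-fold higher number from compound 2 to compound 3 (0.83 log units; beyond the scatter), which involves a different place on the ring; the new step shows that the lower number of compound 2 is not a one-off, since a second chloro placed elsewhere on the ring of compound 3 also gives a lower number, by a step beyond the scatter. Nothing shown here explains why this added chloro lowers the number.

On these data alone, it remains open whether the lower number depends on chloro itself, or whether another group at this same place, such as a fluoro, an amine or a carboxylic acid, would shift the number in the same way or the opposite way. As far as these compounds go, it is also open whether a chloro at this place would give a similar step on a ring lacking the chloro group already present in compound 3.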